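A Methoxy Group on the Core of Compound 1

The compounds below may be only part of what the source reports. "The series", "measured", "known", "first", "only" and "open" are said of these compounds alone.

Compound 1 `CCn1c(=O)/c(=C2\Sc3ccccc3N2C)s/c1=C\c1ccncc1Nc1ccccc1C` is the starting point of this comparison. Going by the values given here, in a functional assay on CWR22R cells (Homo sapiens) for inhibition (on this read-out lower numbers stand for stronger inhibition and higher numbers for weaker inhibition), compound 1 gives 470 nM, the lowest of the three numbers measured so far. Compound 2 `CCn1c(=O)/c(=C2\Sc3cc(F)ccc3N2C)s/c1=C\c1ccncc1Nc1ccccc1C` gives 2300 nM in this assay, and compound 3 `CCn1c(=O)/c(=C2\Sc3ccccc3N2C)s/c1=C\c1ccncc1Nc1cc(F)ccc1F` gives 1100 nM; both steps away from compound 1 lie beyond the scatter, so compound 1 is the most potent of the three.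

Compound 4 `CCn1c(=O)/c(=C2\Sc3ccc(OC)cc3N2C)s/c1=C\c1ccncc1Nc1ccccc1C` differs from compound 1 in a single place: methoxy in place of hydrogen on an aromatic carbon. One measured step resembles this change, since it also introduces a new group on the shared core rather than elsewhere in the molecule, and it weakened inhibition: a 4.9-fold higher number from compound 1 to compound 2 (0.69 log units; beyond the scatter). The other step, a 2.3-fold higher number from compound 1 to compound 3 (0.37 log units; beyond the scatter), alters a different part of the molecule and bears less directly on the question. Among the compounds with values here, no measurement of a methoxy group at this place exists, so the one comparable step is the main guide, and a weaker number is expected for compound 4, of a size in the same region. For compound 4 a value of 1500 nM is estimated, with a range from 500 nM to 5000 nM, which is expected to amount to a 3.2-fold higher number from compound 1 to compound 4 (0.50 log units; beyond the scatter).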

Compound 4, half-maximal inhibitory concentration: 410 nM
Compound 4: the middle estimate sits 3.7-fold (0.56 log units) above what was measured; measured number outside the range, below it.
By their numbers in this assay, from the lowest: compounds 4 and 1 (each within the scatter of the next); then compound 3; then compound 2.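

Methoxy in place of hydrogen on this aromatic carbon of the shared core leaves inhibition in this assay within the scatter, with a 1.1-fold lower number from compound 1 to compound 4 (0.06 log units; within the scatter), so compound 1 and compound 4 cannot be told apart on this read-out. Before this result, the only step that put a new group on the core was a 4.9-fold higher number from compound 1 to compound 2 (0.69 log units; beyond the scatter), which on its own could suggest that any addition to this ring costs inhibition; compound 4 shows that this does not hold for every added group or every carbon of the ring, and that a group of two heavy atoms can be accommodated here without a measurable loss. Nothing available explains why methoxy at this place behaves so differently from the fluoro of compound 2.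

The compounds shown leave open whether another group on this same aromatic carbon, such as a hydroxyl, an amine or a longer chain like ethoxy, would stay within the scatter of compound 1 or move the number in either direction. They also leave open whether methoxy would be accommodated as well in a compound carrying the 2,5-difluorophenyl of compound 3.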